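The source may report more compounds than this note shows. Statements on the series, on what has been measured and on what is new or still open speak of the compounds shown alone.

Measured in a functional assay on U-937 cells (Homo sapiens) for cytotoxicity, read by MTT assay, with a stated time of 24 h; a lower number here means a stronger inhibitor, a higher number a weaker inhibitor:
- compound 1 `Brc1ccc(Oc2cc(Br)cc(Br)c2OCCCCCN2CCN(c3ccccc3)CC2)c(Br)c1`: 42.5 ug/mL
- compound 2 `COc1ccccc1N1CCN(CCCCCOc2c(Br)cc(Br)cc2Oc2ccc(Br)cc2Br)CC1`: 37.5 ug/mL
- compound 3 `BrCCOc1c(Br)cc(Br)cc1Oc1ccc(Br)cc1Br`: 32.5 ug/mL

Compound 2, at 37.5 ug/mL, lies within the scatter of both compound 1 and compound 3, so the three values give no ranking.

The next structure is compound 4 `Brc1ccc(Oc2cc(Br)cc(Br)c2OCCCCCN2CCN(C/C=C/c3ccccc3)CC2)c(Br)c1`. The change is 3-phenylprop-2-en-1-yl in place of 2-methoxyphenyl on an amine nitrogen in a ring.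

Going by the values given here, only one measured step bears on this position. In a 1.1-fold lower number from compound 1 to compound 2 (0.05 log units; within the scatter), methoxy replaces hydrogen on an aromatic carbon of the group on that nitrogen. Among the compounds with values here, it is small, but it is a much narrower change than the one here, and no measured compound carries 3-phenylprop-2-en-1-yl, so the support is weak. Nothing beyond the scatter is expected in this assay, in either direction.

The expected change is a 1.1-fold lower number from compound 2 to compound 4 (0.06 log units; within the scatter). For compound 4 the estimated value is 33 ug/mL, with an expected range of 15 ug/mL to 60 ug/mL.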

Compound 4, half-maximal inhibitory concentration: 32.7 ug/mL
Estimate against measurement, compound 4: 1.0-fold (0.00 log units) above; low and high end bracket the measured number.
By their numbers in this assay, from the lowest: compounds 3, 4, 2 and 1 (each within the scatter of the next).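

Working from this assay, the group on the amine nitrogen in the ring has now been exchanged for one of a different kind, not merely substituted: a 1.1-fold lower number from compound 2 to compound 4 (0.06 log units; within the scatter), and a 1.3-fold lower number from compound 1 to compound 4 (0.11 log units; within the scatter). Both steps stay within the scatter, so 3-phenylprop-2-en-1-yl, with its double bond outside aromatic rings and no hydrogen-bond acceptor, reads the same here as 2-methoxyphenyl or phenyl on that nitrogen, and this position has yet to show any step beyond the scatter. No measurement on hand offers an explanation for these results.

As far as these compounds go, it remains open whether a carboxylic acid or a primary amine on the terminal phenyl ring would shift the number beyond the scatter. The same question stands for a longer chain carrying the six-membered ring with its two nitrogens.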